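The compounds below may be only part of what the source reports. "The series", "measured", "known", "first", "only" and "open" are said of these compounds alone.

Compound 1 `O=C(CCCCCONC(=O)Nc1cccc2cccnc12)NO`: 1000 nM
Compound 2 `COc1cc(NC(=O)NOCCCCCC(=O)NO)c2ncccc2c1`: 400 nM

In a functional assay on A2780cisR cells (Homo sapiens) for antiproliferative activity, read by MTT assay, with a stated time of 72 h (on this read-out higher numbers stand for weaker inhibition and lower numbers for stronger inhibition), compound 2 holds the lower of the two numbers at 400 nM, and compound 1 stands higher at 1000 nM. Compound 3 `COc1cc(NC(=O)NOCCCCCC(=O)NO)c2nccc(C)c2c1` differs from compound 2 by one change: methyl in place of hydrogen on an aromatic carbon. This is methyl in place of hydrogen on an aromatic carbon, on the six-membered aromatic ring with 1 nitrogen, opposite the ring nitrogen. Among the measured compounds shown here, one measured step bears on it only loosely: a 2.5-fold lower number from compound 1 to compound 2 (0.40 log units; beyond the scatter), with methoxy in place of hydrogen on an aromatic carbon. For the measured compounds named here, that step involves a different group, and no measured step covers methyl. A small shift toward a lower number in this assay is therefore expected, quite possibly none beyond the scatter. The expected change is a 1.1-fold lower number from compound 2 to compound 3 (0.06 log units; within the scatter). For compound 3 the estimated value is 350 nM, with an expected range of 130 nM to 900 nM.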

Compound 3, half-maximal inhibitory concentration: 300 nM
Compound 3: middle estimate off by 1.2-fold (0.07 log units), on the high side; low and high end bracket the measured number.
By their numbers in this assay, from the lowest: compounds 3 and 2 (each within the scatter of the next); then compound 1.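

In this assay, methyl in place of hydrogen on an aromatic carbon, opposite the ring nitrogen, gives a 1.3-fold lower number from compound 2 to compound 3 (0.12 log units; within the scatter), so this carbon carries one added heavy atom with no shift beyond the scatter. Among the compounds shown here, this is the first reading at this position: the earlier step, a 2.5-fold lower number from compound 1 to compound 2 (0.40 log units; beyond the scatter), concerned methoxy at a different carbon, and compound 3 retains that methoxy. No supporting measurement is available to explain the result of the methyl change.

From the compounds shown here alone, whether an amine, a carboxylic acid or a longer chain at this carbon would move the number beyond the scatter remains open. Also open, going by these compounds, is whether methyl at this carbon would give a similar result on compound 1, which lacks the methoxy.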